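A few compounds are considered here, and "the series" means these few. Any claim that something is new, unique, unknown or untested is made for them only; others in the source may bear on it.

Four fused bicyclic amines are compared in an assay on HEK293 cells for displacement of a labelled ligand from Neuronal acetylcholine receptor; alpha3/beta4 (Rattus norvegicus), with a stated time of 4 h; a lower number here means a stronger inhibitor, a higher number a weaker inhibitor. Among the measured compounds shown here, compound 1 `CO[C@H]1CC=C2CCN(C)[C@H]2C1` is the only one with a number: in this assay compound 1 gives 100000 nM. Compound 2 `CN1CC[C@@H]2CC[C@H](O)C[C@@H]21` reaches only the limit of the assay, > 300000 nM. Compound 3 `O[C@H]1CC[C@H]2CCN[C@H]2C1` likewise stops at the limit, > 300000 nM. Compound 3 differs from compound 2 by hydrogen in place of methyl on an amine nitrogen in a ring, and the step that the two limits leave unreadable from compound 2 to compound 3 cannot be sized because of the limit of > 300000 nM in this assay, at which 2 of the 3 values shown sit. Compound 4 `CO[C@H]1CC=C2CCN[C@H]2C1` awaits measurement; it differs from compound 1 by hydrogen in place of methyl on an amine nitrogen in a ring. This is the same kind of change, not the same: in compound 3 the place also lies two ring bonds from the ring atom that bears a fused ring. How the core of compound 1 differs from the core of compound 2 is not broken down here. With a step that the two limits leave unreadable from compound 2 to compound 3 unreadable, the expectation rests on compound 1 alone, and the expected step is modest, a 1.5-fold higher number from compound 1 to compound 4 (0.18 log units; within the scatter). Compound 4 is therefore estimated at 150000 nM, between 30000 nM and 500000 nM.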

Compound 4, inhibition constant: > 300000 nM
Compound 4 was reported as a limit; the forecaster's own chance of this, stated with the estimate: 40%; at least 2.0-fold (0.30 log units) between middle value and limit.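

In this assay, hydrogen in place of methyl on an amine nitrogen in a ring gives an at least 3.0-fold higher number from compound 1 to compound 4 (0.47 log units; beyond the scatter), so on the core of compound 1 this change weakens binding beyond the scatter. As far as these compounds go, the value of compound 4 is a limit, so the full size of this step stays unknown. The same change from compound 2 to compound 3 cannot be read, so nothing shows whether its size carries from one core to another, because the values stop at a limit: the limit of > 300000 nM in this assay, at which 3 of the 4 values shown sit.

The compounds shown leave open what a longer chain, such as ethyl or propyl, on the same amine nitrogen would do in this assay. Also open, from the compounds shown here alone, is how a hydroxyl in place of the methoxy group on the core of compound 1 would read.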